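The compounds below may be only part of what the source reports. "The series", "measured", "known", "first", "only" and "open" are said of these compounds alone.

Measured compounds:
compound 1, `COc1ccc(-c2cc(/C=C/C(=O)c3ccc(N)cc3)[nH]n2)cc1`: -75%
compound 2, `COc1cc(-c2cc(/C=C/C(=O)c3ccc(Cl)c(Cl)c3)[nH]n2)cc(OC)c1OC`: 6%

In a functional assay on MDA-MB-435 cells (Homo sapiens) for cytotoxicity, read by sulforhodamine B assay, with a stated time of 48 h, tested at 100 uM (on this read-out higher numbers stand for a weaker effect at the one concentration tested and lower numbers for a stronger effect), compound 1 gives -75%, and in this assay compound 2 gives 6%. Of the two numbers, compound 2 stands highest, and the gap down to compound 1 lies beyond the scatter, so compound 2 shows the weaker effect of the pair at the single concentration tested. The two compounds differ in more than one place, so nothing can be said about which change carries that gap; only the two values themselves are known.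

Compound 3, `COc1ccc(C(=O)/C=C/c2cc(-c3cc(OC)c(OC)c(OC)c3)n[nH]2)cc1`, is the unmeasured compound. It differs from compound 2 in one place: 4-methoxyphenyl in place of 3,4-dichlorophenyl on a carbonyl carbon. The rest of compound 3 is that of compound 2.

Among the compounds with values here, no step between measured compounds with a single change is available, so the expectation for compound 3 rests on the spread between compound 1 and compound 2 alone. The step expected is a number 31 percentage points lower from compound 2 to compound 3 (beyond the scatter), downward and beyond the scatter, but not reaching the value of compound 1. For compound 3 the estimated value is -25%, within -65% to 20%.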

Compound 3, a percentage reported as activity, at one concentration (the size of the read-out at that concentration, not a potency): -44%
The estimate for compound 3 lay 19 percentage points above the measured number; the measured number falls inside the stated range.
By their numbers in this assay, from the lowest: compound 1; then compound 3; then compound 2.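

Putting 4-methoxyphenyl in place of 3,4-dichlorophenyl on a carbonyl carbon, with the rest of the molecule unchanged, gives in this assay a number 50 percentage points lower from compound 2 to compound 3 (beyond the scatter), the only single change among these compounds. The aryl group at this position can therefore alter the read-out by itself, a point that the comparison of compound 1 and compound 2, which differ in more than one place, could not establish; the two groups are equal in heavy atoms, while the group that enters brings oxygen and one hydrogen-bond acceptor and the one that leaves brings two chlorine atoms. Nothing at hand shows which of these differences, if any, lies behind the step.

From the compounds shown here alone, with a single step, it remains open whether the methoxy group, the loss of the two chlorine atoms, or both together carry the change. Also open, going by these compounds, is how a carboxylic acid, a morpholine or a longer alkoxy chain on this ring would read out, and whether the same exchange would have a similar effect with other groups on the rest of the molecule.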